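This account rests on a few compounds, and the source may have more. Where it says the series, first, only, none or still open, it means among the compounds named here.

Compound 1 `Fc1ccc(-c2nn3c(NC4CCCC4)cccc3c2-c2ccnc(NC3CCCC3)n2)cc1` gives in an ADME assay on Vero cells (Chlorocebus sabaeus) for cytotoxicity; a lower number here means that less compound is tolerated, a higher number that more compound is tolerated > 160000 nM, which is a limit of the assay rather than a number.
Compound 2 `COc1ccc(-c2nn3ccc(NC(C)C)cc3c2-c2ccnc(NC3CCCC3)n2)cc1` gives in this assay > 40000 nM, again only a limit.
Compound 3 `Fc1ccc(-c2nn3c(NC4CCCC4)cc(NC4CCCC4)cc3c2-c2ccnc(NC3CCCC3)n2)cc1` gives in this assay > 40000 nM, once more a limit.

Compound 3 thus stands only at a limit, and the two other values shown are limits as well: the limit of > 160000 nM in this assay, at which 1 of the 3 values shown sits, and (the limit of > 40000 nM in this assay, at which 2 of the 3 values shown sit). Within the data shown here, the one change between measured compounds that differ in a single place, a step that the two limits leave unreadable from compound 1 to compound 3, has a limit at each end and so yields no readable size; it adds a cyclopentylamino group on an aromatic carbon, not the change considered next. Compound 4 `CSc1cc(NC2CCCC2)cc2c(-c3ccnc(NC4CCCC4)n3)c(-c3ccc(F)cc3)nn12` differs from compound 3 in one place: methylsulfanyl in place of cyclopentylamino on an aromatic carbon. Among the measured compounds shown here, no measured step bears on this change, so no size can be derived for it in either direction, and nothing beyond the usual scatter is expected; the most likely outcome is that compound 4 again comes back at a limit. Compound 4 is therefore expected to show about 60000 nM in this assay, somewhere between 20000 nM and 200000 nM, the estimated step being a step that the limit leaves unreadable from compound 3 to compound 4.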

Compound 4, half-maximal cytotoxic concentration: > 40000 nM
Compound 4 ended at the assay's limit; the forecaster's own chance of this, stated with the estimate: 70%; the middle value does not contradict the limit.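

Compound 3 and compound 4 both stop at a limit of the assay rather than a number, so swapping cyclopentylamino for methylsulfanyl gives no readable step: the limit of > 40000 nM in this assay, at which 3 of the 4 values shown sit.
The compounds shown leave open at what concentration any of them harms the cells in this assay and whether these two groups differ at all.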